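The source may hold more compounds than are shown below. What is called first, only, known or untested is meant among the compounds shown, and "the series" means these compounds.

The account opens with two measured compounds. Compound 1 `Brc1cccc(Nc2nc3ncccc3n2Cc2ccccc2)c1` was tested in a functional assay on HCT-116 cells (Homo sapiens) for antiproliferative activity, read by MTT assay, with a stated time of 72 h (a higher number here means a weaker inhibitor of growth, a lower number a stronger inhibitor of growth), where compound 1 gives 77700 nM. Compound 2 `Cn1nc(-c2ccnc(Nc3cccc(O)c3)n2)c2ccccc21` gives 17200 nM in this assay; of the two numbers recorded, compound 2 holds the lower one, and its gap to compound 1 lies beyond the usual scatter. Within the data shown here, no pair of measured compounds differing in a single place is available, so there is no measured step from which the size of one change can be read.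

Compound 3 `Cc1cccc(Nc2nccc(-c3nn(C)c4ccccc34)n2)c1` is the next compound to be measured. It differs from compound 2 by the change (methyl in place of hydroxy on an aromatic carbon), that is, methyl in place of hydroxy on an aromatic carbon, meta to a large group on a six-membered aromatic ring of carbon only. Among the measured compounds shown here, the data hold no measured step to show what this exchange is worth in this assay. Compound 3 is therefore expected to land near compound 2, with a shift that may not exceed the scatter. The step expected here is a 1.5-fold higher number from compound 2 to compound 3 (0.16 log units; within the scatter), a mild weakening at most. Compound 3 is estimated at 25000 nM, with a range from 8000 nM to 80000 nM.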

Compound 3, concentration for 50% growth inhibition: 9420 nM
Compound 3: the middle estimate sits 2.7-fold (0.42 log units) above what was measured; measured number inside the range.
By their numbers in this assay, from the lowest: compounds 3 and 2 (each within the scatter of the next); then compound 1.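

In this assay, among these compounds, the exchange of hydroxy for methyl on this aromatic carbon, meta to a large group, gives the first measured step, a 1.8-fold lower number from compound 2 to compound 3 (0.26 log units; within the scatter), so the size of one change can now be read directly. At this place, a group counted with a hydrogen-bond donor and a hydrogen-bond acceptor and a group counted with neither give numbers that cannot be told apart, although this rests on a single pair and says nothing about other places on the ring. No independent measurement bears on this result, so it stands as a comparison of numbers alone.

Going by these compounds, whether an amine, a carboxylic acid or a longer chain at this same place would also stay within the scatter of compound 2 and compound 3 remains open, as both groups compared here count only one heavy atom. Compound 1 differs from both in more than one place, so whether this exchange would read the same way on the core of compound 1 is also left open.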